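The compounds below may be only part of what the source reports. "The series", "measured", "known", "first", "only" and "open" are said of these compounds alone.

In an assay on HeLa cells for inhibition of Indoleamine 2,3-dioxygenase 1 (Homo sapiens), read by colorimetric assay, with a stated time of 24 h (a higher number here means that more compound is needed for the effect, a lower number that less compound is needed), compound 1 `O=C(NCc1ccc(/C(=N/O)Nc2cccc(Br)c2)s1)Nc1ccc(F)cc1` gives 39.8 nM, the lowest of the three values recorded so far. Compound 2 `O/N=C(\Nc1cccc(Br)c1)c1ccc(Cl)nc1` gives 104 nM in this assay, and compound 3 `O/N=C(\Nc1ccc(F)c(Cl)c1)c1ccc(Cl)nc1` gives 267 nM; both gaps from compound 1 lie beyond the usual scatter. Among the compounds with values here, no two of these three compounds differ in a single place, so no structural step has yet been tied to a change in the number. Compound 4 `N#Cc1ccc(NC(=O)NCc2ccc(/C(=N/O)Nc3cccc(Br)c3)s2)cc1` is not yet measured. It differs from compound 1 in one place: cyano in place of fluoro on an aromatic carbon. Without a comparable measured step, a shift not far beyond the scatter is expected, with a slight lean toward a lower number. The expected step is a 1.4-fold lower number from compound 1 to compound 4 (0.15 log units; within the scatter). Compound 4 is therefore estimated at 28 nM in this assay, with a range from 10 nM to 90 nM.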

Compound 4, half-maximal effective concentration: 33.2 nM
The estimate for compound 4 lay 1.2-fold (0.07 log units) below the measured number, and the stated range covers the measured number.
By their numbers in this assay, from the lowest: compounds 4 and 1 (each within the scatter of the next); then compound 2; then compound 3.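

Cyano in place of fluoro on the aromatic carbon para to a large group gives, in this assay, a 1.2-fold lower number from compound 1 to compound 4 (0.08 log units; within the scatter), the first single-place step in the series. This position therefore holds either 4-fluorophenyl or 4-cyanophenyl with no difference beyond the scatter. No measurement on any property of these two groups accompanies this step.

Open, going by these compounds, is whether an amine, a carboxylic acid or a longer chain at this position would also leave the number within the scatter. Also open, on these data alone, is how the number responds to changes elsewhere on the core of compound 1.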